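Amino Substitution on Two Cores and Growth Inhibition

The compounds below may be only part of what the source reports. "The series", "measured", "known", "first", "only" and "open" are said of these compounds alone.

Measured compounds: compound 1 `COc1ncnc2c1c(-c1ccsc1)cn2[C@@H]1O[C@H](CO)[C@@H](O)[C@H]1O` gives 140 nM in a functional assay on HCT-116 cells (Homo sapiens), read by MTT assay, with a stated time of 72 h; on this read-out lower numbers stand for stronger inhibition and higher numbers for weaker inhibition. Compound 2 `COc1nc(N)nc2c1c(-c1ccsc1)cn2[C@@H]1O[C@H](CO)[C@@H](O)[C@H]1O` reaches only the limit of this assay, > 20000 nM. Compound 3 `O=c1[nH]cnc2c1c(-c1ccccc1)cn2[C@@H]1O[C@H](CO)[C@@H](O)[C@H]1O` likewise reaches only the limit of this assay, > 20000 nM.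

The change from compound 1 to compound 2 is amino in place of hydrogen on an aromatic carbon, and it brings an at least 140-fold higher number from compound 1 to compound 2 (2.15 log units; beyond the scatter). How the core of compound 1 differs from the core of compound 3 is not broken down here. Compound 4 `Nc1nc2c(c(-c3ccccc3)cn2[C@@H]2O[C@H](CO)[C@@H](O)[C@H]2O)c(=O)[nH]1` has not yet been measured; it arises from compound 3 by amino in place of hydrogen on an aromatic carbon. This is the same kind of change as before, though the surroundings differ: the place is meta to a group of 1 heavy atom here, whereas it was meta to a methoxy group (2 heavy atoms) before. Compound 3 already stands at the limit of > 20000 nM in this assay, at which 2 of the 3 values shown sit, so no worsening could be seen even if the change acts as it did from compound 1 to compound 2. Compound 4 is therefore expected to give 25000 nM, most likely again as a limit rather than a number. The estimate means a step that the limit leaves unreadable from compound 3 to compound 4, expected only because compound 3 rests at the limit of > 20000 nM in this assay, at which 2 of the 3 values shown sit.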

Compound 4, half-maximal inhibitory concentration: > 20000 nM
Compound 4 was reported as a limit (the forecaster's own chance of this, stated with the estimate: 90%); the middle value lies beyond the limit too.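

Compound 3 and compound 4 are both reported as a limit and not as a number, so no step can be read between them, because both rest at the same end of the range: the limit of > 20000 nM in this assay, at which 3 of the 4 values shown sit.

The compounds shown leave open whether amino in place of hydrogen changes the result for the core of compound 3 in this assay at all.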